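Replacing phenoxy by chloro: notes on compound 4

This account rests on a few compounds, and the source may have more. Where it says the series, first, only, none or still open, it means among the compounds named here.

Measured compounds:
compound 1 `O=C1/C(=C\c2cccc(Oc3ccccc3)c2)c2ccccc2N1c1c(Cl)cccc1Cl` — > 100 ug/mL
compound 2 `O=C1/C(=C\c2ccc(F)cc2)c2ccccc2N1c1c(Cl)cccc1Cl` — 38 ug/mL
compound 3 `COc1ccc(/C=C2\C(=O)N(c3c(Cl)cccc3Cl)c3ccccc32)cc1` — > 100 ug/mL

In a functional assay on B16-F10 cells (Homo sapiens) for cytotoxicity against B16-F10 (Mus musculus), read by MTT assay, with a stated time of 72 h (a lower number here means that less compound is needed, a higher number that more compound is needed for the effect), compound 1 gives only a limit, > 100 ug/mL, and no number. The same limit is reported for compound 3, > 100 ug/mL. Within the data shown here, compound 2, the one measured compound with a number, gives 38 ug/mL. Among the measured compounds shown here, the only measured step is an at least 2.6-fold higher number from compound 2 to compound 3 (0.42 log units; beyond the scatter); it concerns the same position of the shared core but neither phenoxy nor chloro, so it bears on the present question only indirectly. Relevant here is the limit of > 100 ug/mL in this assay, at which 2 of the 3 values shown sit.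

The step to compound 4 `O=C1/C(=C\c2cccc(Cl)c2)c2ccccc2N1c1c(Cl)cccc1Cl` is chloro in place of phenoxy on an aromatic carbon. The closest measured parallel is compound 2, where a small halogen at this ring gives 38 ug/mL. Compound 4 is therefore expected near 40 ug/mL (range 15 ug/mL to 100 ug/mL). That estimate implies an expected step of an at least 2.5-fold lower number from compound 1 to compound 4 (0.39 log units; beyond the scatter), though the starting point is a limit and the size is uncertain.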

Compound 4, concentration for half-maximal effect: 8 ug/mL
The estimate for compound 4 lay 5.0-fold (0.70 log units) above the measured number; measured number outside the range, below it.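

In this assay, chloro in place of phenoxy gives an at least 12-fold lower number from compound 1 to compound 4 (1.09 log units; beyond the scatter), and the 3-chlorophenyl group also clearly improves on 4-methoxyphenyl, with an at least 12-fold lower number from compound 3 to compound 4 (1.09 log units; beyond the scatter). Even against the 4-fluorophenyl group it gives a 4.8-fold lower number from compound 2 to compound 4 (0.68 log units; beyond the scatter), so a halogen on this ring does not by itself set the value. The steps from compound 1 and compound 3 are minimum sizes, as both start from a limit of the assay: the limit of > 100 ug/mL in this assay, at which 2 of the 4 values shown sit.

Between compound 2 and compound 4, the halogen and its place change together, so neither can be credited alone. As far as these compounds go, how an amine or a carboxylic acid would fare at this place stays open.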